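The source may report more compounds than this note shows. Statements on the series, on what has been measured and on what is new or still open speak of the compounds shown alone.

Measured compounds in this series:

compound 1 `O=c1c(C(=S)Nc2ccccc2)coc2cc(Cl)ccc12`: > 100000 nM
compound 2 `O=c1c(C(=S)Nc2ccccc2)coc2cc(Cl)c(Cl)cc12`: > 100000 nM
compound 3 `O=c1c(C2N=C(c3ccccc3)SS2)coc2cc(Cl)ccc12`: 76700 nM

Among the compounds with values here, in a functional assay on COLO 205 cells (Homo sapiens) for inhibition, read by sulforhodamine B assay, with a stated time of 48 h (a lower number here means a stronger inhibitor, a higher number a weaker inhibitor), compound 3 gives 76700 nM, the only number in the set. Compound 1 reaches only the limit of this assay, > 100000 nM. Compound 2 likewise sits at the limit, > 100000 nM. The difference between the cores of compound 2 and compound 3 is not broken down here.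

The change from compound 2 to compound 1 is hydrogen in place of chloro on an aromatic carbon; the step that the two limits leave unreadable from compound 2 to compound 1 cannot be read because of the limit of > 100000 nM in this assay, at which 2 of the 3 values shown sit.

Compound 4 `O=c1c(C2N=C(c3ccccc3)SS2)coc2ccccc12` is not yet measured. It arises from compound 3 by hydrogen in place of chloro on an aromatic carbon. This is the same kind of change as that from compound 2 to compound 1, not the same: around the place in compound 2 the carbon is also ortho to a chloro group, which is absent in compound 3.

Within the data shown here, with the only analogous step unreadable, the expectation for compound 4 rests on compound 3 and its value 76700 nM alone: the step of a 1.6-fold higher number from compound 3 to compound 4 (0.19 log units; within the scatter) is expected to be small to moderately weakening. Compound 4 is thus estimated at 120000 nM, expected within 40000 nM to 400000 nM.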

Compound 4, half-maximal inhibitory concentration: > 100000 nM
Compound 4: only a limit was reported; the forecaster's own chance of this, stated with the estimate: 55%; the middle value lies beyond the limit too.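

In this assay compound 4 gives > 100000 nM, which is a limit of the assay and not a number. Within the data shown here, the change of hydrogen in place of chloro on the core of compound 3 therefore appears only as a floor, an at least 1.3-fold higher number from compound 3 to compound 4 (0.11 log units; that floor lies within the scatter), so the data show neither a step beyond the scatter nor its true size, only that compound 4 ends at the limit of the assay. The same kind of change on the core of compound 2 cannot be read either, so nothing here shows whether the change carries from one core to the other, and neither agreement nor disagreement between the two cores can be claimed, because both steps run into the same ceiling: the limit of > 100000 nM in this assay, at which 3 of the 4 values shown sit.

Among these compounds, compound 3 is the only compound in the set with a number, so no step between two measured numbers is available, and what the chloro contributes on either core remains unsettled. Going by these compounds, it also stays open whether an amine, a methoxy group or a carboxylic acid in place of the chloro would give values clear of the limit, where the size of such a change could be read.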